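A Methyl Added on a Saturated Chain Carbon

The source may hold more compounds than are shown below. What is called first, only, known or untested is meant among the compounds shown, and "the series" means these compounds.

In an ADME assay on MT4 cells (Homo sapiens) for cytotoxicity, read by MTT assay, with a stated time of 4 days (a higher number here means that more compound is tolerated, a lower number that less compound is tolerated), compound 1 (`CCC(c1cc(=O)[nH]c(N(C)C)n1)c1c(F)cccc1F`) gives 73000 nM. Compound 2 (`Cc1c(C(C)c2c(F)cccc2F)nc(N(C)C)[nH]c1=O`) has no exact number in this assay and stands only at a limit, > 17000 nM.

Compound 3 (`CCC(c1nc(N(C)C)[nH]c(=O)c1C)c1c(F)cccc1F`) follows from compound 2 by one structural change, methyl in place of hydrogen on a saturated chain carbon, two bonds along the chain from two aromatic carbons. Cut one bond further out, the same difference reads methyl to ethyl.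

Within the data shown here, no measured step shows what this change does in this assay, so only a small upward step, none beyond the scatter, is expected. Among the measured compounds shown here, the one exact number, 73000 nM for compound 1, supports the expectation that tolerance stays high. The expected step that the limit leaves unreadable from compound 2 to compound 3 reflects this. For compound 3 the estimated value is 30000 nM, with an expected range from 12000 nM to 75000 nM.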

Compound 3, half-maximal cytotoxic concentration: > 81000 nM
Compound 3 ended at the assay's limit (the forecaster's own chance of this, stated with the estimate: 45%); middle value at least 2.7-fold (0.43 log units) from the limit.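

In this assay compound 3 stands only at a limit, > 81000 nM. Compound 2 is also held at a limit, so the step for methyl in place of hydrogen on a saturated chain carbon cannot be read and this change still has no size. Among these compounds, the other change, methyl in place of hydrogen on an aromatic carbon, gives an at least 1.1-fold higher number from compound 1 to compound 3 (0.04 log units; that floor lies within the scatter), the first readable step, and it shows that the ethyl compound keeps a high tolerance with that methyl present.

From the compounds shown here alone, how far compound 3 really lies from compound 1 stays open, as only a floor is available for that step. Also open, going by these compounds, is what a longer chain such as propyl, or an amine, would do on the saturated chain carbon.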